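Dichlorophenyl amide rearrangement on the shared core

The compounds below may be only part of what the source reports. "The series", "measured", "known", "first", "only" and "open" are said of these compounds alone.

All numbers below come from a functional assay on M14 cells (Homo sapiens) for antiproliferative activity, read by sulforhodamine B assay, with a stated time of 48 h; on this read-out higher numbers stand for weaker inhibition and lower numbers for stronger inhibition.

compound 1 `COc1cc(-c2nn(-c3ccc(NC(=O)c4cc(Cl)cc(Cl)c4)cc3)cc2-c2ccncc2)ccc1Cl` gives 7390 nM
compound 2 `O=C(Nc1ccc(-n2cc(-c3ccncc3)c(-c3ccc(Cl)c(O)c3)n2)cc1)Nc1ccc(Cl)c(C(F)(F)F)c1` gives 1430 nM
compound 3 `O=C(Nc1ccc(-n2cc(-c3ccncc3)c(-c3ccc(Cl)c(O)c3)n2)cc1)c1ccc(Cl)c(Cl)c1` gives 2350 nM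

Compound 3 stands second highest of the three numbers; its nearest neighbour is compound 2, and the two values lie within the scatter of each other, while the number of compound 1 is clearly higher than that of compound 3. Compound 4 `O=C(Nc1ccc(-n2cc(-c3ccncc3)c(-c3ccc(Cl)c(O)c3)n2)cc1)c1cc(Cl)cc(Cl)c1` is not yet measured. It differs from compound 3 in one place: 3,5-dichlorophenyl in place of 3,4-dichlorophenyl on a carbonyl carbon.

Going by the values given here, no measured step moves chlorine around this ring. Among the compounds with values here, the only measured step, a 1.6-fold higher number from compound 2 to compound 3 (0.22 log units; within the scatter), exchanges the whole group on the carbonyl carbon and stays within the scatter, so it gives little guidance. Compound 1 also carries the 3,5-dichlorophenyl, but it differs from compound 3 in a second place as well, so its higher number cannot be assigned to the ring change alone. The expectation for compound 4 in this assay is therefore a step of a 1.5-fold higher number from compound 3 to compound 4 (0.17 log units; within the scatter), leaning towards a somewhat higher number but possibly none beyond the scatter. Compound 4 is estimated at 3500 nM, within 1500 nM to 9000 nM.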

Compound 4, half-maximal inhibitory concentration: 1510 nM
The estimate for compound 4 lay 2.3-fold (0.37 log units) above the measured number, and the stated range covers the measured number.
By their numbers in this assay, from the lowest: compounds 2, 4 and 3 (each within the scatter of the next); then compound 1.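

Moving chlorine on the ring at the carbonyl carbon, with 3,5-dichlorophenyl in place of 3,4-dichlorophenyl, gives in this assay a 1.6-fold lower number from compound 3 to compound 4 (0.19 log units; within the scatter) and so separates the two patterns by nothing beyond the scatter. Exchanging the whole group, with 3,5-dichlorophenyl in place of (4-chloro-3-(trifluoromethyl)phenyl)amino, gives a 1.1-fold higher number from compound 2 to compound 4 (0.02 log units; within the scatter) and likewise separates nothing, so the three groups at this place in compounds 2, 3 and 4 cannot be ranked. With 3,5-dichlorophenyl held constant, hydrogen in place of methyl on an oxygen on an aromatic ring gives a 4.9-fold lower number from compound 1 to compound 4 (0.69 log units; beyond the scatter) and thus places the higher number of compound 1 with that methyl and not with the chlorine pattern.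

Still open, from the compounds shown here alone, is how a saturated group such as cyclohexyl, or a dimethylamino substituent on the ring, would behave at the carbonyl carbon. No independent data bear on these results.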